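Glucagon receptor series: fused indazole in place of substituted pyrazole

The source may hold more compounds than are shown below. What is called first, only, known or untested is meant among the compounds shown, and "the series" means these compounds.

Measured compounds, with their numbers in an assay on cells for displacement of a labelled ligand from Glucagon receptor (Homo sapiens), in the presence of a further agent that is not named here; on this read-out lower numbers stand for stronger inhibition and higher numbers for weaker inhibition:
compound 1 `CCCC(Oc1ccc(-n2cc(Cl)cn2)cc1)c1ccc(C(=O)NCCC(=O)O)cc1`: 1100 nM
compound 2 `CCCC(Oc1ccc(-n2cc(C(=O)N(C)C)cn2)cc1)c1ccc(C(=O)NCCC(=O)O)cc1`: 6500 nM
compound 3 `CCCC(Oc1ccc(-n2cc(C(F)(F)F)cn2)cc1)c1ccc(C(=O)NCCC(=O)O)cc1`: 890 nM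

Compound 3 gives the lowest of the three numbers. One step is a 1.2-fold lower number from compound 1 to compound 3 (0.09 log units; within the scatter), so these two cannot be told apart; the other step is a 7.3-fold lower number from compound 2 to compound 3 (0.86 log units; beyond the scatter), which does separate them. In the three measured compounds only the small group carried on the five-membered aromatic ring has been varied.

Compound 4 `CCCC(Oc1ccc(-n2cc3ccccc3n2)cc1)c1ccc(C(=O)NCCC(=O)O)cc1` carries 2H-indazol-2-yl in place of 4-(trifluoromethyl)-1H-pyrazol-1-yl on an aromatic carbon. Neither measured step covers this kind of change: a 1.2-fold lower number from compound 1 to compound 3 (0.09 log units; within the scatter) and a 7.3-fold lower number from compound 2 to compound 3 (0.86 log units; beyond the scatter) compare small groups on the same five-membered ring, whereas compound 4 exchanges that ring system for one with a fused six-membered aromatic ring of carbon only. The two steps show that this position accepts one exchange without a visible step and shows a modest step for another, so a step of either sign remains possible for compound 4. Compound 4 is expected to sit near compound 3, with an estimated step of a 1.7-fold higher number from compound 3 to compound 4 (0.23 log units; within the scatter) in this assay and wide uncertainty. The estimate for compound 4 is 1500 nM, expected within 400 nM to 6000 nM.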

Compound 4, inhibition constant: 290 nM
Compound 4: middle estimate off by 5.2-fold (0.71 log units), on the high side, and the stated range ends above it.
By their numbers in this assay, from the lowest: compound 4; then compounds 3 and 1 (each within the scatter of the next); then compound 2.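

In this assay the fused 2H-indazol-2-yl separates from all three substituted pyrazoles, with a 3.1-fold lower number from compound 3 to compound 4 (0.49 log units; beyond the scatter) and a 3.8-fold lower number from compound 1 to compound 4 (0.58 log units; beyond the scatter) and a 22-fold lower number from compound 2 to compound 4 (1.35 log units; beyond the scatter) all beyond the scatter, so compound 4 gives the lowest number in the set. The position on the six-membered aromatic ring therefore accepts a fused six-membered aromatic ring of carbon only, and here that exchange separates from trifluoromethyl and chloro, which themselves cannot be told apart. No measurement at hand accounts for this step.

Going by these compounds, it remains open whether the lower number depends on the fused ring staying carbon only, or would hold with a ring nitrogen in its place. On these data alone, how a methoxy or an amine on the fused ring of compound 4 would shift the number is also open.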